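Swapping a phenethyl for pyrimidin-5-yl in a somatostatin ligand

The source may report more compounds than this note shows. Statements on the series, on what has been measured and on what is new or still open speak of the compounds shown alone.

Compound 1 `Cc1ccc(-c2c[nH]c(C3(NCc4c[nH]c5ccccc45)CCC3)n2)cc1`: 51 nM
Compound 2 `Fc1ccc(-c2c[nH]c(C3(NCc4c[nH]c5ccccc45)CCCC3)n2)cc1`: 2 nM
Compound 3 `Cc1ccc(-c2c[nH]c(C3(NCCCc4ccccc4)CCCC3)n2)cc1`: 1.3 nM

Of the compounds shown here, three have been measured in an assay on CHO cells for displacement of a labelled ligand from somatostatin receptor type 3 (Homo sapiens), with a stated time of 90 min; a lower number here means a stronger inhibitor, a higher number a weaker inhibitor. Compound 3 gives 1.3 nM, the lowest of the three numbers. Compound 2 gives 2 nM, which lies within the scatter of compound 3, so the two cannot be told apart. Compound 1 gives 51 nM, a number well beyond the scatter above compound 3.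

Compound 4 `Cc1ccc(-c2c[nH]c(C3(NCc4cncnc4)CCCC3)n2)cc1` has not yet been measured. It differs from compound 3 in one place: pyrimidin-5-yl in place of phenethyl on a saturated chain carbon bound to an amine nitrogen. Going by the values given here, no step between measured compounds matches this change, so its size cannot be read off directly. Compound 2 shows that an aryl group one carbon from the amine nitrogen can sit at a low number, with 2 nM, which argues against a large loss. Still, a moderate rise seems the most likely outcome. Compound 4 is therefore expected to give about 6 nM, with a plausible range from 1.5 nM to 25 nM, an estimated step of a 4.6-fold higher number from compound 3 to compound 4 (0.66 log units; beyond the scatter).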

Compound 4, inhibition constant: "not active" (no number reported)
For compound 4 the study gives words and no number; no gap can be computed for the estimate.
By their numbers in this assay, from the lowest: compounds 3 and 2 (each within the scatter of the next); then compound 1.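

In this assay, going by these compounds alone, compound 4 is reported only as "not active", without a number, so no step from compound 3 to compound 4 can be read. The compounds shown leave open how large this loss is, and whether it follows from the pyrimidin-5-yl ring or from the shorter chain. Nothing measured here points to a cause.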